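Series notes: nitro for methoxy on the arylpiperazine

A few compounds are considered here, and "the series" means these few. Any claim that something is new, unique, unknown or untested is made for them only; others in the source may bear on it.

Measured so far in an ADME assay on NIH3T3 cells (Mus musculus) for cytotoxicity, read by MTT assay, with a stated time of 24 h; on this read-out higher numbers stand for weaker inhibition and lower numbers for stronger inhibition:
Compound 1 `O=C(CN1CCN(c2ccccc2)CC1)N1CCN(c2nnc(-c3ccccc3)c(-c3ccccc3)n2)CC1` gives > 963000 nM, a limit of the assay.
Compound 2 `COc1cccc(N2CCN(CC(=O)N3CCN(c4nnc(-c5ccccc5)c(-c5ccccc5)n4)CC3)CC2)c1` gives 361000 nM.
Compound 3 `COc1ccc(N2CCN(CC(=O)N3CCN(c4nnc(-c5ccccc5)c(-c5ccccc5)n4)CC3)CC2)cc1` gives > 910000 nM, a limit of the assay.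

Compound 3 thus stands at a limit, with one further value in this set also a limit (the limit of > 910000 nM in this assay, at which 1 of the 3 values shown sits). Compound 4 `O=C(CN1CCN(c2ccc([N+](=O)[O-])cc2)CC1)N1CCN(c2nnc(-c3ccccc3)c(-c3ccccc3)n2)CC1` differs from compound 3 by nitro in place of methoxy on an aromatic carbon. Among the compounds with values here, no measured step covers this change. The step that the two limits leave unreadable from compound 1 to compound 3 is unreadable, and the step of an at least 2.5-fold higher number from compound 2 to compound 3 (0.40 log units; beyond the scatter) concerns the position of methoxy, not its replacement. On this basis compound 4 is expected to remain near the limit in this assay. Compound 4 is estimated at 800000 nM, between 250000 nM and 1000000 nM. This estimate means a step of an at least 1.1-fold lower number from compound 3 to compound 4 (0.05 log units; that floor lies within the scatter).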

Compound 4, half-maximal inhibitory concentration: > 886000 nM
Compound 4 was reported as a limit; the forecaster's own chance of this, stated with the estimate: 65%; middle value at least 1.1-fold (0.04 log units) away from the limit.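

In this assay compound 4 gives > 886000 nM, which is a limit of the assay, so nitro para to a large group yields no number to set against methoxy. The steps from compound 1 and from compound 3 to compound 4 cannot be read, as both ends of each are limits. Within the data shown here, the one readable step is an at least 2.4-fold higher number from compound 2 to compound 4 (0.38 log units; beyond the scatter), and the 3-methoxyphenyl group of compound 2 remains the only one here with a measured value.

Still open, from the compounds shown here alone, is whether an amine or a carboxylic acid at this place would give a value rather than a limit. Also open, going by these compounds, is whether nitro would give a value where compound 2 carries its methoxy.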